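A few compounds are considered here, and "the series" means these few. Any claim that something is new, unique, unknown or untested is made for them only; others in the source may bear on it.

Compound 1 `Cc1n[nH]c2ccc(-c3nc4cnc(N5CCN(C)CC5)cn4c3Nc3ccc(F)cc3)cc12` shows how weak this series can be: in a functional assay on MV4-11 cells (Homo sapiens) for inhibition, with a stated time of 120 h (a lower number here means a stronger inhibitor, a higher number a weaker inhibitor), compound 1 gives 32300 nM. Compound 2 `Cc1n[nH]c2ccc(-c3nc4cnc(N5CCN(C)CC5)cn4c3Nc3cccc(Cl)c3)cc12` shares the whole core and the methylpiperazine group, differing only in the aryl group on the ring nitrogen, yet in this assay compound 2 gives "not determined" (no result reported), so no single number places it. Compound 3 `Cc1n[nH]c2ccc(-c3nc4cnc(N5CCN(C)CC5)cn4c3Nc3ccc(Br)cc3)cc12` follows from compound 2 by a small exchange at the same site: 4-bromophenyl in place of 3-chlorophenyl on a nitrogen on an aromatic ring, with a halogen kept but moved and enlarged, one six-membered ring of carbon leaving and another entering. Among the compounds with values here, no measured pair shows what such an exchange does here, so no step size is known from the data. Given that the only anchor, compound 1, lies at 32300 nM, compound 3 is expected to remain a weak inhibitor, with an estimated value near 20000 nM and a plausible range from 4000 nM to 80000 nM.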

Compound 3, half-maximal inhibitory concentration: 2600 nM
Compound 3: the middle estimate sits 7.7-fold (0.89 log units) above what was measured, and the stated range ends above it.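

Bromo in place of fluoro on an aromatic carbon of the aryl group brings a 12-fold lower number from compound 1 to compound 3 (1.09 log units; beyond the scatter) in this assay and nothing else in the molecule changes. This shows that the series is not uniformly weak and that a single halogen exchange on this aryl group can shift the result beyond the scatter, while the step from compound 2 to compound 3 cannot be read, as compound 2 has no number. Nothing given here accounts for the lower number with bromo.

Going by these compounds, it remains open where 4-chlorophenyl would fall relative to compound 1 and compound 3, and whether 3-bromophenyl would match compound 3. Also open, on these data alone, is how the aryl group would behave with an amine or a carboxylic acid in place of the halogen.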